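The compounds below may be only part of what the source reports. "The series", "measured", "known", "first", "only" and "open" are said of these compounds alone.

Measured so far in an ADME assay on microsomes from liver (Homo sapiens) for pharmacokinetics, read by LC-MS, with a stated time of 60 min, tested at 1 uM; on this read-out lower numbers stand for slow clearance and higher numbers for fast clearance:

- compound 1 `O=C(NCc1ccc(S(=O)(=O)c2ccccc2)cc1)N1Cc2ccncc2C1` gives 7.5 mL/min/kg
- compound 2 `CC(C)n1cc(S(=O)(=O)c2ccc(CNC(=O)N3Cc4ccncc4C3)cc2)cn1` gives 4 mL/min/kg

Among the measured compounds shown here, compound 2 lies within the scatter of compound 1, the only other measured compound. Compound 3 `O=C(NCc1ccc(S(=O)(=O)C2CCC(F)(F)CC2)cc1)N1Cc2ccncc2C1` carries 4,4-difluorocyclohexyl in place of 1-isopropyl-1H-pyrazol-4-yl on a sulfonyl sulfur. For the measured compounds named here, the one measured step at this place is a 1.9-fold lower number from compound 1 to compound 2 (0.27 log units; within the scatter) and it replaced phenyl with 1-isopropyl-1H-pyrazol-4-yl. Going by the values given here, no measured compound has a non-aromatic ring there, so this single step is only a weak guide. The expected move is a 1.8-fold higher number from compound 2 to compound 3 (0.24 log units; within the scatter) and so none beyond the scatter. Compound 3 is expected at 7 mL/min/kg (estimated range 3.5 mL/min/kg to 14 mL/min/kg).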

Compound 3, clearance: 6 mL/min/kg
Compound 3: middle estimate off by 1.2-fold (0.07 log units), on the high side; measured number inside the range.
By their numbers in this assay, from the lowest: compounds 2, 3 and 1 (each within the scatter of the next).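

In this assay the swap to 4,4-difluorocyclohexyl on the sulfonyl sulfur gives two steps (a 1.5-fold higher number from compound 2 to compound 3 (0.18 log units; within the scatter) and a 1.3-fold lower number from compound 1 to compound 3 (0.10 log units; within the scatter)) that both stay within the scatter. A non-aromatic ring of carbon only therefore reads the same here as the two aromatic groups, so ring type has not yet separated these compounds on clearance. Nothing at hand explains why the three groups read alike.

As far as these compounds go, whether any group at this place can shift clearance beyond the scatter stays open. An amine, a carboxylic acid or an open carbon chain on the sulfonyl sulfur might behave differently, and these compounds cannot tell.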